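Demethylating the Aryl Ether of Compound 1

The source may hold more compounds than are shown below. What is called first, only, known or untested is meant among the compounds shown, and "the series" means these compounds.

Compound 1 `COc1cc(-c2nn(-c3ccc(NC(=O)Nc4cccc(Cl)c4Cl)cc3)cc2-c2ccncc2)ccc1Cl` was tested in a functional assay on A375P cells (Homo sapiens) for antiproliferative activity, read by MTT assay, with a stated time of 48 h (a lower number here means a stronger inhibitor, a higher number a weaker inhibitor), where compound 1 gives > 20000 nM, a limit of the assay rather than a number. Compound 2 `COc1cc(-c2nn(-c3ccc(NC(=O)c4cc(Cl)cc(Cl)c4)cc3)cc2-c2ccncc2)ccc1Cl` has 3,5-dichlorophenyl in place of (2,3-dichlorophenyl)amino on a carbonyl carbon; in this assay compound 2 gives > 20000 nM, again a limit. The step that the two limits leave unreadable from compound 1 to compound 2 is therefore unreadable, with both values at the limit of > 20000 nM in this assay, at which 2 of the 2 values shown sit. Compound 3 `O=C(Nc1ccc(-n2cc(-c3ccncc3)c(-c3ccc(Cl)c(O)c3)n2)cc1)Nc1cccc(Cl)c1Cl` carries hydrogen in place of methyl on an oxygen on an aromatic ring, methoxy to hydroxy. Going by the values given here, no measured step bears on this change, and compound 1 stands only at a limit, so no step beyond the scatter can be predicted. Compound 3 is expected to give 20000 nM, between 5000 nM and 60000 nM, an expected step of a number no higher from compound 1 to compound 3 (the limit leaves the size open).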

Compound 3, half-maximal inhibitory concentration: 16800 nM
Estimate against measurement, compound 3: 1.2-fold (0.08 log units) above, and the stated range covers the measured number.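

In this assay, methoxy to hydroxy on the aromatic ring yields the first readable number among the compounds shown, with an at least 1.1-fold lower number from compound 1 to compound 3 (0.07 log units; that floor lies within the scatter). The full size of this step stays unknown, and compound 1 stands only at a limit, so the change is not shown to exceed the scatter. Compound 3 is the only compound shown that gives a number rather than a limit: the limit of > 20000 nM in this assay, at which 2 of the 3 values shown sit.

Still open, going by these compounds, is how an amine or an ethoxy group at this oxygen-bearing position would read. On these data alone, it is also open whether hydroxy would give a number on the 3,5-dichlorophenyl amide of compound 2.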